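Ring Swap on the Carbamate: Morpholine to Pyrrolidine

This account rests on a few compounds, and the source may have more. Where it says the series, first, only, none or still open, it means among the compounds named here.

Compound 1 `Nc1nc(-c2ccccc2)cc(-c2cccc(OC(=O)N3CCCCC3)c2)n1`: 1.95 nM
Compound 2 `Nc1nc(-c2ccccc2)cc(-c2cccc(OC(=O)N3CCOCC3)c2)n1`: 2.65 nM

In an assay (strain Sprague-Dawley) for displacement of a labelled ligand from adenosine receptor A1 (Rattus norvegicus), read by scintillation counting, with a stated time of 1 h (a higher number here means a weaker inhibitor, a lower number a stronger inhibitor), compound 1 gives 1.95 nM and compound 2 gives 2.65 nM. Compound 2 carries the larger of the two numbers, but a 1.4-fold higher number from compound 1 to compound 2 (0.13 log units; within the scatter) sits within the scatter, so the two cannot be told apart. Compound 3 `Nc1nc(-c2ccccc2)cc(-c2cccc(OC(=O)N3CCCC3)c2)n1` is not yet measured; it differs from compound 2 by pyrrolidin-1-yl in place of morpholin-4-yl on a carbonyl carbon. Within the data shown here, the only step that bears on this is a 1.4-fold higher number from compound 1 to compound 2 (0.13 log units; within the scatter), a ring exchange on the same carbonyl carbon that changed little. Compound 3 is therefore expected to give 2 nM (range 0.9 nM to 5 nM), an expected step of a 1.3-fold lower number from compound 2 to compound 3 (0.12 log units; within the scatter) that stays within the scatter.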

Compound 3, inhibition constant: 0.835 nM
For compound 3 the middle estimate is 2.4-fold (0.38 log units) above the measured one; measured number outside the range, below it.
By their numbers in this assay, from the lowest: compound 3; then compounds 1 and 2 (each within the scatter of the next).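

In this assay the ring on the carbonyl carbon now makes a readable difference: pyrrolidin-1-yl in place of morpholin-4-yl gives a 3.2-fold lower number from compound 2 to compound 3 (0.50 log units; beyond the scatter) and pyrrolidin-1-yl in place of piperidin-1-yl gives a 2.3-fold lower number from compound 1 to compound 3 (0.37 log units; beyond the scatter) and both steps are modest but beyond the scatter. The swap between the two six-membered rings showed no such separation, so this position does respond to a ring exchange. Nothing available here explains the lower number. Still open, going by these compounds, is how azetidin-1-yl, or an open-chain dimethylamino group, would read on the same carbonyl carbon.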